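The compounds below may be only part of what the source reports. "The series", "measured", "known", "first", "only" and "open" are said of these compounds alone.

Of the compounds shown here, three have so far been measured in a functional assay on MCF7 cells (Homo sapiens) for cytotoxicity, read by sulforhodamine B assay, with a stated time of 48 h; on this read-out lower numbers stand for stronger inhibition and higher numbers for weaker inhibition. Compound 1 `O=C(NCCCCl)Nc1ccc(S(=O)(=O)Oc2ccc(O)cc2)cc1` gives 51000 nM. Compound 2 `CCNC(=O)Nc1ccc(S(=O)(=O)Oc2ccccc2C)cc1` gives 4500 nM, and compound 3 `CCNC(=O)Nc1ccc(S(=O)(=O)Oc2ccccc2CC)cc1` gives 3400 nM. Within the data shown here, the only single-place step among them, a 1.3-fold lower number from compound 2 to compound 3 (0.12 log units; within the scatter), is within the scatter. Compound 3 thus holds the lowest of the three numbers, but compound 2 stands within the scatter of it, and only compound 1 stands clearly apart with a higher number.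

Compound 4 `CCNC(=O)Nc1ccc(S(=O)(=O)Oc2ccc(O)cc2)cc1` differs from compound 3 in one place: 4-hydroxyphenyl in place of 2-ethylphenyl on an oxygen. Among the measured compounds shown here, no measured step covers this exchange; the one measured step concerns only a small change on a chain, not the ring on the oxygen. Compound 1 carries the same 4-hydroxyphenyl group, with a different chain on the urea, and its number 51000 nM set against compound 3 at 3400 nM hints, without proving, that the hydroxyphenyl ring goes with a higher number. Compound 4 is therefore expected to give 15000 nM, within a range of 4000 nM to 50000 nM. The expected step of a 4.4-fold higher number from compound 3 to compound 4 (0.64 log units; beyond the scatter) is toward a higher number, beyond the scatter, though with wide uncertainty.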

Compound 4, half-maximal inhibitory concentration: 8000 nM
For compound 4 the middle estimate is 1.9-fold (0.27 log units) above the measured one, within the range that was stated.
By their numbers in this assay, from the lowest: compounds 3, 2 and 4 (each within the scatter of the next, the first and the last beyond it); then compound 1.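

In this assay, 4-hydroxyphenyl in place of 2-ethylphenyl on the oxygen bound to the sulfonyl sulfur gives a 2.4-fold higher number from compound 3 to compound 4 (0.37 log units; beyond the scatter), a modest change, while 4-hydroxyphenyl in place of 2-methylphenyl gives a 1.8-fold higher number from compound 2 to compound 4 (0.25 log units; within the scatter). The ring on this oxygen can therefore be exchanged with little effect on the number in these pairs. The larger step lies in the chain: with 4-hydroxyphenyl held fixed, hydrogen in place of chloromethyl on a saturated chain carbon, two bonds along the chain from an amide-type nitrogen, gives a 6.4-fold lower number from compound 1 to compound 4 (0.80 log units; beyond the scatter), so the high number of compound 1 goes with its chain rather than its ring.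

Nothing available gives a reason for any of these steps. From the compounds shown here alone, how a phenyl ring carrying an amine or a carboxylic acid would compare on this oxygen stays open, as does a longer chain without chlorine.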